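The source may report more compounds than this note shows. Statements on the series, on what has been measured and on what is new or still open speak of the compounds shown alone.

Measured so far in a functional assay on HL-60 cells (Homo sapiens) for antiproliferative activity, read by trypan blue exclusion, with a stated time of 48 h; on this read-out lower numbers stand for stronger inhibition and higher numbers for weaker inhibition:
Compound 1, `CC1(C)OC(=O)C2(C(=O)O1)[C@@H](c1ccc(-c3ccc(O)cc3)cc1)CC(=O)C[C@H]2c1ccccc1`: in this assay compound 1 gives 8000 nM.
Compound 2, `CC1(C)OC(=O)C2(C(=O)O1)[C@@H](c1ccc(-c3ccc(CO)cc3)cc1)CC(=O)C[C@H]2c1ccccc1`: in this assay compound 2 gives 20000 nM.

On these two numbers compound 2 stands highest. For the measured compounds named here, its nearest neighbour is compound 1, and the step of a 2.5-fold higher number from compound 1 to compound 2 (0.40 log units; beyond the scatter) lies beyond the scatter; this single exchange, hydroxymethyl in place of hydroxy on an aromatic carbon, is the only measured step in the set.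

Compound 3, `CC1(C)OC(=O)C2(C(=O)O1)[C@@H](c1ccc(-c3ccc(-c4ccc(O)cc4)cc3)cc1)CC(=O)C[C@H]2c1ccccc1`, has not yet been measured in this assay. It differs from compound 2 in one place: 4-hydroxyphenyl in place of hydroxymethyl on an aromatic carbon. Going by the values given here, no measured step bears directly on this change. Among the compounds with values here, the one known step, a 2.5-fold higher number from compound 1 to compound 2 (0.40 log units; beyond the scatter), concerns hydroxy against hydroxymethyl at the same place and cannot be carried over to the entry of a further aromatic ring. What can be said is that compound 3 again carries a hydroxy on an aromatic carbon, as compound 1 does, while the entering group brings its own ring. A modest step downward is therefore expected, a 2.0-fold lower number from compound 2 to compound 3 (0.30 log units; within the scatter), with a wide range. Compound 3 is estimated at 10000 nM, within a range from 3000 nM to 40000 nM.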

Compound 3, half-maximal inhibitory concentration: 16000 nM
Compound 3: the middle estimate sits 1.6-fold (0.20 log units) below what was measured; the range from low to high includes it.
By their numbers in this assay, from the lowest: compounds 1, 3 and 2 (each within the scatter of the next, the first and the last beyond it).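

In this assay, the position on an aromatic carbon para to a large group accepts 4-hydroxyphenyl, with its additional six-membered aromatic ring, in place of hydroxymethyl without a change that can be told from the scatter (a 1.3-fold lower number from compound 2 to compound 3 (0.10 log units; within the scatter)), and the same holds against hydroxy (a 2.0-fold higher number from compound 1 to compound 3 (0.30 log units; within the scatter)). For the compounds shown here, compound 3 thus lies within the scatter of both compound 1 and compound 2, while only the pair compound 1 and compound 2 stands apart beyond it, so the series shows no clear penalty or gain for this much larger group and no order can be set for compound 3 against either neighbour. Nothing on hand explains this tolerance at the position.

Open, as far as these compounds go, is whether the hydroxy carried by 4-hydroxyphenyl matters at all, a question that a plain phenyl in the same place would address. Also open, from the compounds shown here alone, is whether an amine, a carboxylic acid or a longer chain at this position would shift the number beyond the scatter, and in which direction, given that all three compounds so far lie close together.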